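Moving the phenyl hydroxyl from compound 1 to compound 4

The source may hold more compounds than are shown below. What is called first, only, known or untested is meant among the compounds shown, and "the series" means these compounds.

Compound 1 `Cn1cnc2c(N3CCCCC3)nc(-c3ccccc3O)nc21` is measured in an assay on cells for displacement of a labelled ligand from adenosine receptor A1 (Homo sapiens), read by scintillation counting and radioligand binding, with a stated time of 60 min, tested at 10 uM (on this read-out lower numbers stand for less inhibition and higher numbers for more inhibition at the one concentration tested (going by the name of the read-out)), at 50.5%. Among the two plain numbers recorded, compound 1 stands highest; compound 3 `Clc1ccc(-c2nc(N3CCCCC3)c3nc[nH]c3n2)cc1Cl` gives 24.1%, a gap beyond the usual scatter. Compound 2 `CN1CCN(c2nc(-c3cccc(Cl)c3)nc3[nH]cnc23)CC1` is reported only as a limit of the assay, > 80%; this is the limit of > 80% in this assay, at which 1 of the 3 values shown sits. Compound 4 `Cn1cnc2c(N3CCCCC3)nc(-c3cccc(O)c3)nc21` has not yet been measured. The change from compound 1 is 3-hydroxyphenyl in place of 2-hydroxyphenyl on an aromatic carbon. Among the compounds with values here, no step between measured compounds isolates this change, so the size of the step in this assay cannot be read from the series; a shift of modest size in either direction, possibly within the scatter, is expected. Compound 4 is estimated at 45%, within 20% to 72%, an expected step of a number 5.5 percentage points lower from compound 1 to compound 4 (within the scatter).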

Compound 4, a percentage reported as inhibition, at one concentration (the size of the read-out at that concentration, not a potency): 78.5%
Estimate against measurement, compound 4: 33.5 percentage points below; the measured number lies above the stated range.
By their numbers in this assay, from the lowest: compound 3; then compound 1; then compound 4. At a limit, above all of these: compound 2.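

3-hydroxyphenyl in place of 2-hydroxyphenyl gives a number 28 percentage points higher from compound 1 to compound 4 (beyond the scatter) in this assay. Within the data shown here, this is the first step that isolates a single place, and it shows that the read-out responds to where the hydroxyl sits on the phenyl ring, although the counts of atoms, donors and acceptors stay the same. The data shown give no cause for this step.

Still open, on these data alone, is how a 4-hydroxyphenyl group would read at this position. Also open, as far as these compounds go, is whether a methoxy group or an amine in place of the hydroxyl would hold the higher reading of compound 4.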